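Ring-closing the imidazole nitrogen substituent on a melanocortin receptor 4 ligand

This account rests on a few compounds, and the source may have more. Where it says the series, first, only, none or still open, it means among the compounds named here.

Measured compounds:
compound 1, `COc1ccc(Br)cc1CCc1c(Cl)cccc1-c1nccn1C`, 300 nM
compound 2, `COc1ccc(Br)cc1CCc1c(Cl)cccc1-c1nccn1C(C)C`, 670 nM
compound 3, `CCCn1ccnc1-c1cccc(Cl)c1CCc1cc(Br)ccc1OC`, 1300 nM

Of the compounds shown here, three sharing the same core have been measured in an assay on isolated protein for binding affinity to Melanocortin receptor 4 (Homo sapiens); a higher number here means a weaker inhibitor, a lower number a stronger inhibitor. Compound 1 carries a methyl on the imidazole nitrogen and gives 300 nM, the lowest of the three numbers. Replacing that methyl by isopropyl gives compound 2 with 670 nM, a step of a 2.2-fold higher number from compound 1 to compound 2 (0.35 log units; beyond the scatter). Compound 3, with a propyl on the same nitrogen, gives 1300 nM, a step of a 4.3-fold higher number from compound 1 to compound 3 (0.64 log units; beyond the scatter) from compound 1; the step of a 1.9-fold higher number from compound 2 to compound 3 (0.29 log units; within the scatter) from compound 2 to compound 3 stays within the scatter.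

Compound 4, `COc1ccc(Br)cc1CCc1c(Cl)cccc1-c1ncc2n1CCC2`, has not yet been measured. It differs from compound 1 in that (a group of 8 heavy atoms (6 carbon, 2 nitrogen; one five-membered non-aromatic ring with 1 hetero atom, one five-membered aromatic ring with 2 hetero atoms) in place of a group of 6 heavy atoms (4 carbon, 2 nitrogen; one five-membered aromatic ring with 2 hetero atoms), on an aromatic carbon). The new group ties the nitrogen substituent back into a second five-membered non-aromatic ring. Both measured steps from compound 1 bear on this: each time the methyl was enlarged, the number rose modestly. Compound 4 adds carbon at the same nitrogen, so a modest rise is expected, not a fall. The step from compound 1 to compound 4 is estimated at a 1.8-fold higher number from compound 1 to compound 4 (0.26 log units; within the scatter). Compound 4 is therefore expected to give 550 nM, within a range of 200 nM to 1500 nM.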

Compound 4, inhibition constant: 180 nM
Compound 4: the middle estimate sits 3.1-fold (0.49 log units) above what was measured; measured number below the stated range.
By their numbers in this assay, from the lowest: compounds 4 and 1 (each within the scatter of the next); then compounds 2 and 3 (each within the scatter of the next).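

In this assay, the step of a 1.7-fold lower number from compound 1 to compound 4 (0.22 log units; within the scatter) shows that extra carbon at this imidazole nitrogen need not cost anything once it is tied back into a five-membered non-aromatic ring, whereas both open chains had raised the number. The groups in compound 2, compound 3 and compound 4 all count 8 heavy atoms, yet the ring stands clearly apart from the chains, with steps of a 3.7-fold lower number from compound 2 to compound 4 (0.57 log units; beyond the scatter) and a 7.2-fold lower number from compound 3 to compound 4 (0.86 log units; beyond the scatter), so at this position the arrangement of the added carbon matters and not only the amount. Nothing in the data explains why the closed ring behaves differently from the isopropyl and propyl chains.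

The compounds shown leave open whether a six-membered non-aromatic ring in place of the five-membered one would stay level with compound 1 or fall back towards the open chains. They also leave open how a hydroxyl group or an amine on the new ring would change the number, and whether the ring gives the same result with the bromo and chloro groups of the shared core replaced.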